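The compounds below may be only part of what the source reports. "The series", "measured", "known", "first", "only" and "open" are said of these compounds alone.

In a functional assay on HCT-116 cells (Homo sapiens) for cytotoxicity, read by MTT assay, with a stated time of 48 h (on this read-out higher numbers stand for weaker inhibition and lower numbers for stronger inhibition), compound 1, `CCCCOc1ccc2c(Cl)ccnc2c1`, gives 2740 nM. Compound 2, `CCCCCCCCOc1ccc2c(Cl)ccnc2c1`, carries butyl in place of hydrogen on a saturated chain carbon, four bonds along the chain from an oxygen on an aromatic ring; in this assay compound 2 gives 2820 nM, so the step is a 1.0-fold higher number from compound 1 to compound 2 (0.01 log units; within the scatter). Compound 3, `CCOc1ccc2c(NCCN(C)C)ccnc2c1`, is built on a different core; how its core differs from that of compound 1 is not broken down here. In this assay compound 3 gives 2570 nM, and all three numbers lie within the scatter of one another, so none of them can be set apart.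

Compound 4, `CCCCCCOc1ccc2c(NCCN(C)C)ccnc2c1`, has not yet been measured. It carries butyl in place of hydrogen on a saturated chain carbon, two bonds along the chain from an oxygen on an aromatic ring. Among the measured compounds shown here, this is the same kind of change as the one between compound 1 and compound 2, though not the same: there the butyl entered on a saturated chain carbon four bonds along the chain from an oxygen on an aromatic ring, here it enters on a saturated chain carbon two bonds along the chain from an oxygen on an aromatic ring. Because the step of a 1.0-fold higher number from compound 1 to compound 2 (0.01 log units; within the scatter) stayed within the scatter, a step of similar size is expected here: a 1.0-fold higher number from compound 3 to compound 4 (0.01 log units; within the scatter). Compound 4 is therefore estimated at 2600 nM in this assay, most likely between 1200 nM and 5600 nM.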

Compound 4, half-maximal inhibitory concentration: 850 nM
For compound 4 the middle estimate is 3.1-fold (0.49 log units) above the measured one; measured number outside the range, below it.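

On the second core, extending the ethoxy chain to hexyloxy gives a 3.0-fold lower number from compound 3 to compound 4 (0.48 log units; beyond the scatter) in this assay, a modest gain in cytotoxic strength. Set beside the earlier step, this shows that adding a butyl does not carry over unchanged from one core to the other: the same change on two cores in this assay, a 1.0-fold higher number (0.01 log units; within the scatter) from compound 1 to compound 2 and a 3.0-fold lower number (0.48 log units; beyond the scatter) from compound 3 to compound 4, 3.1-fold (0.49 log units) apart, beyond the scatter of two such steps

Among the compounds shown here, this does not show why the two steps differ, since each core offers only one pair, and the cores are not the only difference: the butyl enters four bonds along the chain from the oxygen in one pair and two bonds along in the other.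

Still open, on these data alone, is whether a longer chain, such as octyloxy, on the core of compound 3 would lower the number further or whether the gain would level off. Also open, as far as these compounds go, is whether ethoxy and hexyloxy chains on the core of compound 1 would separate the effect of the core from that of the starting chain.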